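Swapping the aryl group for a long chain

The source may hold more compounds than are shown below. What is called first, only, known or untested is meant among the compounds shown, and "the series" means these compounds.

Compound 1 `CC(=O)N1c2ccccc2CCC1C(=O)Nc1cc(C(F)(F)F)cc(C(F)(F)F)c1` sits only at a limit of the assay, > 70000 nM.
Compound 2 `CCCC(=O)N1c2ccccc2CCC1C(=O)Nc1cc(C(F)(F)F)cc(C(F)(F)F)c1` gives 21900 nM.
Compound 3 `O=C(Nc1cc(C(F)(F)F)cc(C(F)(F)F)c1)C1CCc2ccccc2N1C(=O)c1ccc(Cl)cc1` gives 2220 nM.

In a functional assay on HCT-15 cells (Homo sapiens) for cytotoxicity, read by sulforhodamine B assay, with a stated time of 72 h (a higher number here means a weaker inhibitor of growth, a lower number a stronger inhibitor of growth), compound 3 holds the lower of the two actual numbers, and its gap to compound 2, a 9.9-fold lower number from compound 2 to compound 3 (0.99 log units; beyond the scatter), lies beyond the scatter. Compound 4 `CCCCCCCCC(=O)N1c2ccccc2CCC1C(=O)Nc1cc(C(F)(F)F)cc(C(F)(F)F)c1` differs from compound 3 by octyl in place of 4-chlorophenyl on a carbonyl carbon. Among the measured compounds shown here, two measured steps bear on this change: an at least 3.1-fold lower number from compound 1 to compound 2 (0.50 log units; beyond the scatter), where a longer chain on the carbonyl lowered the number, and a 9.9-fold lower number from compound 2 to compound 3 (0.99 log units; beyond the scatter), where the aryl group lowered it further still. Removing that aryl group is therefore expected to raise the number modestly, though the longer octyl chain may offset part of the loss. Compound 4 is expected to give 6000 nM, within 1500 nM to 25000 nM, a step of a 2.7-fold higher number from compound 3 to compound 4 (0.43 log units; beyond the scatter).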

Compound 4, concentration for 50% growth inhibition: 4970 nM
Compound 4: the middle estimate sits 1.2-fold (0.08 log units) above what was measured, and the stated range covers the measured number.
By their numbers in this assay, from the lowest: compound 3; then compound 4; then compound 2. At a limit, above all of these: compound 1.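

On this carbonyl carbon, a long chain lowers the number well beyond what the shorter chain gave, with octyl showing a 4.4-fold lower number from compound 2 to compound 4 (0.64 log units; beyond the scatter). The step measured from a limit gives only a bound, an at least 14-fold lower number from compound 1 to compound 4 (1.14 log units; beyond the scatter): the limit of > 70000 nM in this assay, at which 1 of the 4 values shown sits.
Octyl still does not match the 4-chlorophenyl, showing a 2.2-fold higher number from compound 3 to compound 4 (0.35 log units; beyond the scatter), so a chain without a ring comes close to the aryl group but stays behind it.

As far as these compounds go, whether a chain longer than octyl, or one ending in an amine or a carboxylic acid, would lower the number further stays open. So does the outcome with a plain phenyl in place of 4-chlorophenyl.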